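Extending a methoxy group on a weak phosphatase inhibitor

A few compounds are considered here, and "the series" means these few. Any claim that something is new, unique, unknown or untested is made for them only; others in the source may bear on it.

Compound 1 `CCCNc1nn2c(=O)cc(C(F)(F)F)nc2s1` and compound 2 `CCCCNc1nn2c(=O)cc(C(F)(F)F)nc2s1` share a core that carries a trifluoromethyl group and an alkylamino chain. In an ADME assay on cells for inhibition of Intestinal-type alkaline phosphatase (Homo sapiens), read by luminescence, with stated times of 7 min and 20 min (a higher number here means a weaker inhibitor, a lower number a stronger inhibitor), compound 1 gives 310 nM. In this assay compound 2 gives 710 nM. The change between them is methyl in place of hydrogen on a saturated chain carbon, three bonds along the chain from a nitrogen on an aromatic ring, and it made a step of a 2.3-fold higher number from compound 1 to compound 2 (0.36 log units; beyond the scatter).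

Compound 3 `COc1ccccc1-c1nn2c(=O)cc(C(F)(F)F)nc2s1` carries a methoxyphenyl group on the same core instead. How the core of compound 1 and that of compound 3 differ is not broken down here. In this assay compound 3 reaches only a limit of the method, > 100000 nM, which is not a number but (the limit of > 100000 nM in this assay, at which 1 of the 3 values shown sits).

Compound 4 `CCOc1ccccc1-c1nn2c(=O)cc(C(F)(F)F)nc2s1` has not yet been measured. It differs from compound 3 by methyl in place of hydrogen on a saturated chain carbon bound to an oxygen on an aromatic ring. This is the same kind of change as from compound 1 to compound 2, yet the place differs: earlier the methyl entered on a saturated chain carbon, three bonds along the chain from a nitrogen on an aromatic ring; here it enters on a saturated chain carbon bound to an oxygen on an aromatic ring. Beside the earlier step of a 2.3-fold higher number from compound 1 to compound 2 (0.36 log units; beyond the scatter), a step that the limit leaves unreadable from compound 3 to compound 4 is expected. That expectation rests on compound 3 giving only a limit, > 100000 nM. Compound 4 is therefore estimated at 150000 nM, expected between 60000 nM and 400000 nM.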

Compound 4, half-maximal inhibitory concentration: > 100000 nM
Compound 4 was reported as a limit; the forecaster's own chance of this, stated with the estimate: 85%; the middle value lies beyond the limit too.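

Within the data shown here, compound 3 and compound 4 both sit at a limit of the method rather than at a number, so no step between them can be read: the limit of > 100000 nM in this assay, at which 2 of the 4 values shown sit. The compounds shown leave open whether going from methoxy to ethoxy changes the inhibition at all, and whether that change would match the step seen from compound 1 to compound 2.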